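Methyl for tert-butyl on the aromatic ring of a hydroxamic acid

The source may hold more compounds than are shown below. What is called first, only, known or untested is meant among the compounds shown, and "the series" means these compounds.

The measured compounds:
compound 1, `Cc1ccccc1CN1CC=C(CCC(=O)NO)C1=O`, 4720 nM in a functional assay on HCT-15 cells (Homo sapiens) for inhibition, read by sulforhodamine B assay; on this read-out lower numbers stand for stronger inhibition of growth and higher numbers for weaker inhibition of growth
compound 2, `CC(C)(C)c1ccc(CCCN2CC=C(CCC(=O)NO)C2=O)cc1`, 5100 nM
compound 3, `N#Cc1ccc(CN2CC=C(CCC(=O)NO)C2=O)cc1`, > 10000 nM

Compound 3 reaches only a limit in this assay, which is all that can be said of it (the limit of > 10000 nM in this assay, at which 1 of the 3 values shown sits). Among the two numbers that are not limits, compound 2 carries the higher one, and its nearest neighbour is compound 1, whose number is lower by a margin that sits within the scatter of this assay, so no order between compound 1 and compound 2 can be read from these two values.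

Compound 4, `Cc1ccc(CCCN2CC=C(CCC(=O)NO)C2=O)cc1`, has not yet been measured in this assay. It differs from compound 2 in one place: methyl in place of tert-butyl on an aromatic carbon. Among the measured compounds shown here, nothing among the measured compounds shows this change, so no measured step bears on it directly. The expectation for compound 4 is a step from compound 2 of a 1.2-fold higher number from compound 2 to compound 4 (0.07 log units; within the scatter), that is, no movement beyond the usual scatter, with the number for compound 4 estimated at 6000 nM and likely to fall between 2500 nM and 15000 nM.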

Compound 4, concentration for 50% growth inhibition: 5100 nM
The estimate for compound 4 lay 1.2-fold (0.07 log units) above the measured number; measured number inside the range.
By their numbers in this assay, from the lowest: compounds 1, 2 and 4 (each within the scatter of the next). At a limit, above all of these: compound 3.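

In this assay, putting methyl in place of tert-butyl on this aromatic carbon, para to a large group, gives no change at the digits printed from compound 2 to compound 4 (within the scatter). The earlier compounds shown here could not show this, since none of them formed a pair differing in one place; here, going from 4 heavy atoms to 1 at this position leaves the number where it stood, so for these two groups the read-out does not separate one from the other. Nothing measured here gives a reason for this flat step.

On these data alone, both groups are built of carbon alone, with no hydrogen-bond donors or acceptors, so it remains open whether a group of another kind on this aromatic carbon, such as an amine or a carboxylic acid, would leave the number just as unmoved. As far as these compounds go, it also remains open whether a bare hydrogen at this place, or a longer chain carrying this aromatic ring to the shared core, would give the same reading in this assay.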